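The source may hold more compounds than are shown below. What is called first, only, known or untested is meant among the compounds shown, and "the series" means these compounds.

For the measured compounds named here, compound 2 `Cc1c(N(C)C)nc(CCCCCCCCCCO)c(O)c1C` stands lowest of the two numbers so far: in a functional assay on cells (Lymphocyte), read by a luciferase reporter and ATP content, with a stated time of 48 h, tested at 25 uM (a lower number here means a stronger effect, a higher number a weaker effect of the compound at the concentration tested), compound 2 gives 3%. Its nearest neighbour, compound 1 `CCCCCCCCCCCCCCCCc1c(C)c(N(C)C)nc(C)c1O`, sits far higher, as in this assay compound 1 gives 37%, a gap beyond the usual scatter. Compound 3 `CCCCCCCCCCCCCCCCc1nc(N(C)C)c(C)c(C)c1O` has not yet been measured. It differs from compound 2 by hexyl in place of hydroxy on a saturated chain carbon, ten or more bonds along the chain from an aromatic carbon. Because compound 1 gives 37% with its own long chain, a sizeable step toward a weaker effect is expected, a number 27 percentage points higher from compound 2 to compound 3 (beyond the scatter). Compound 3 is accordingly estimated at 30%, within a range from 8% to 60%.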

Compound 3, a percentage reported as activity, at one concentration (the size of the read-out at that concentration, not a potency): 41%
Compound 3: the middle estimate sits 11 percentage points below what was measured; low and high end bracket the measured number.
By their numbers in this assay, from the lowest: compound 2; then compounds 1 and 3 (each within the scatter of the next).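

Hexyl in place of hydroxy gives a number 38 percentage points higher from compound 2 to compound 3 (beyond the scatter) in this assay. For the compounds shown here, this is the first comparison that changes only one place, and it shows that a change on a saturated chain carbon still matters: the effect at the concentration tested is much weaker with hexyl. Nothing here offers an explanation for this step. Still open, as far as these compounds go, is whether an amine or a carboxylic acid in place of hydroxy would keep the stronger effect, and how a plain decyl chain would compare.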